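Dimethoxyphenyl in place of fluorophenyl on the saturated carbon

The source may hold more compounds than are shown below. What is called first, only, known or untested is meant among the compounds shown, and "the series" means these compounds.

Measured so far:
compound 1, `COc1ccc(C2OC(c3cc(OC)c(OC)c(OC)c3)=NN2C(C)=O)c(OC)c1`, gives -3.1%;
compound 2, `COc1cc(C(=O)N/N=C/c2ccccc2C(F)(F)F)cc(OC)c1OC`, gives 35.6%;
compound 3, `COc1cc(C2=NN(C(C)=O)C(c3ccccc3F)O2)cc(OC)c1OC`, gives 32.8%.

In a functional assay on BGC-823 cells (Homo sapiens) for antiproliferative activity, read by MTT assay, tested at 5 uM (on this read-out higher numbers stand for a stronger effect at the one concentration tested and lower numbers for a weaker effect), compound 3 stands second highest of the three numbers. Compound 2 gives 35.6%, a value within the scatter of the value of compound 3, so no order between those two can be drawn. Among the compounds with values here, compound 1 gives -3.1%, and the single-change step a number 35.9 percentage points higher from compound 1 to compound 3 (beyond the scatter) is the one comparison that bears on what follows.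

Compound 4, `COc1ccc(OC)c(C2OC(c3cc(OC)c(OC)c(OC)c3)=NN2C(C)=O)c1`, differs from compound 3 in one place: 2,5-dimethoxyphenyl in place of 2-fluorophenyl on a saturated ring carbon. This reverses the kind of change seen between compound 1 and compound 3, where a dimethoxyphenyl gave way to a fluorophenyl and the read-out rose markedly. Returning a dimethoxyphenyl, here the 2,5-dimethoxyphenyl, is therefore expected to move this assay downward, by a step beyond the scatter. The estimated step is a number 27.8 percentage points lower from compound 3 to compound 4 (beyond the scatter). Compound 4 is expected to give about 5%, within a range from -10% to 22%.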

Compound 4, a percentage reported as inhibition, at one concentration (the size of the read-out at that concentration, not a potency): 18.2%
Beside the measured number, compound 4's estimate is 13.2 percentage points below it; low and high end bracket the measured number.
By their numbers in this assay, from the lowest: compound 1; then compound 4; then compounds 3 and 2 (each within the scatter of the next).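

In this assay, the change at the saturated ring carbon gives a number 14.6 percentage points lower from compound 3 to compound 4 (beyond the scatter), so a dimethoxyphenyl there again sits lower than 2-fluorophenyl, though by less than in the earlier step of a number 35.9 percentage points higher from compound 1 to compound 3 (beyond the scatter). The new comparison is between the two dimethoxyphenyl groups: a number 21.3 percentage points higher from compound 1 to compound 4 (beyond the scatter) shows that the read-out at this position depends on where the methoxy groups stand on the phenyl ring, not merely on their presence, with 2,5-dimethoxyphenyl above 2,4-dimethoxyphenyl. No measurement here explains these differences. The compounds shown leave open whether this order holds at other concentrations, since each number comes from a single one. They also leave open how a phenyl ring carrying a dimethylamino group or a carboxylic acid would behave at this position.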